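The source may hold more compounds than are shown below. What is called first, only, known or untested is meant among the compounds shown, and "the series" means these compounds.

Among the measured compounds shown here, compound 2, `CC(=O)c1ccc(-c2cn3ccnc3c(-c3ccc4ncn(C5CCCCC5)c4c3)n2)cc1`, gives the lower of the two numbers measured so far: in a functional assay on MCF7 cells (Homo sapiens) for inhibition, read by sulforhodamine B assay, with a stated time of 48 h, tested at 10 uM (a higher number here means more inhibition at the concentration tested (going by the name of the read-out), a lower number less inhibition), compound 2 gives 12%, the lowest of the two numbers. Its nearest neighbour is compound 1, `COc1ccc(-c2cn3ccnc3c(-c3ccc4ncn(C5CCCCC5)c4c3)n2)cc1`, which in this assay gives 80.2%. For the measured compounds named here, the only step measured so far is a number 68.2 percentage points lower from compound 1 to compound 2 (beyond the scatter), a large fall that comes with an acetyl in place of a methoxy on an aromatic carbon.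

Compound 3, `COc1ccccc1-c1cn2ccnc2c(-c2ccc3ncn(C4CCCCC4)c3c2)n1`, is not yet measured. Its change from compound 2 is 2-methoxyphenyl in place of 4-acetylphenyl on an aromatic carbon. Going by the values given here, this step bears directly on the one measured step, since it removes the acetyl and brings a methoxy back, although compound 3 does not simply recreate compound 1, as the two structures show. Because a number 68.2 percentage points lower from compound 1 to compound 2 (beyond the scatter) was large and downward, reversing the acetyl for a methoxy is expected to move the number upward again, though the different arrangement of the entering group leaves the size uncertain.

Compound 3 is therefore expected to give about 55%, within a range of 20% to 85%, which amounts to an estimated step of a number 43 percentage points higher from compound 2 to compound 3 (beyond the scatter).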

Compound 3, a percentage reported as inhibition, at one concentration (the size of the read-out at that concentration, not a potency): 8.4%
Beside the measured number, compound 3's estimate is 46.6 percentage points above it; measured number outside the range, below it.
By their numbers in this assay, from the lowest: compounds 3 and 2 (each within the scatter of the next); then compound 1.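

Moving the methoxy on the phenyl ring, with the rest of the molecule unchanged, is enough to lose nearly all of the inhibition: this assay shows a number 71.8 percentage points lower from compound 1 to compound 3 (beyond the scatter) for 2-methoxyphenyl in place of 4-methoxyphenyl. So the earlier fall seen with the acetyl cannot be read simply as the loss of a methoxy, since a compound that keeps a methoxy also gives a low number; at this position, where the group sits on the phenyl ring matters as well as what the group is. The other comparison gives a number 3.6 percentage points lower from compound 2 to compound 3 (within the scatter), so in this assay 2-methoxyphenyl and 4-acetylphenyl cannot be told apart, and no measurement here explains either result.

The compounds shown leave open whether the high number depends on a methoxy specifically or whether another group at the same place on the phenyl ring, such as an amine, a hydroxyl or a carboxylic acid, could match compound 1. With readings at a single concentration, they also give no potency for any of the three compounds.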